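From chloro to nitro: one swap awaiting its number

The source may hold more compounds than are shown below. What is called first, only, known or untested is meant among the compounds shown, and "the series" means these compounds.

Within the data shown here, in a functional assay on SCC-7 cells (Mus musculus) for inhibition (a higher number here means a weaker inhibitor, a lower number a stronger inhibitor), only two numbers exist so far: compound 1 `COc1cccc2c1[n+]([O-])nc(N)[n+]2[O-]` gives 288000 nM and compound 2 `Nc1n[n+]([O-])c2cc(Cl)ccc2[n+]1[O-]` gives 12200 nM as the lower one. That makes compound 2 the stronger inhibitor of the pair, by a gap beyond the usual scatter of repeat measurements. The two compounds differ in more than one place, so their gap cannot be tied to any single group. It shows only how far apart two members of this series can lie.

Compound 3 `Nc1n[n+]([O-])c2cc([N+](=O)[O-])ccc2[n+]1[O-]` differs from compound 2 in one place, with nitro in place of chloro on an aromatic carbon. Among the measured compounds shown here, no measured pair shows this swap, so what follows is a judgement and not a reading from the data. A moderate move towards a lower number, meaning a stronger inhibitor, seems more likely than no change, though a result within the scatter would not be surprising. The expected change is a 3.1-fold lower number from compound 2 to compound 3 (0.48 log units; beyond the scatter) as an estimate. For compound 3 the estimated value is 4000 nM with 800 nM to 15000 nM as the expected range.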

Compound 3, half-maximal inhibitory concentration: 2800 nM
Estimate against measurement, compound 3: 1.4-fold (0.15 log units) above; measured number inside the range.
By their numbers in this assay, from the lowest: compound 3; then compound 2; then compound 1.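

Among these compounds, this is the first pair that differs in one place only, so a change in this assay can now be tied to a single group: putting nitro in place of chloro on an aromatic carbon of the six-membered carbon ring gives a 4.4-fold lower number from compound 2 to compound 3 (0.64 log units; beyond the scatter). The step lies beyond the usual scatter of repeat measurements, so the group at this position does matter, and nitro, with more heavy atoms than chloro, is accepted there with a gain in inhibition rather than a loss. Nothing measured alongside these numbers explains why the swap has this effect.

As far as these compounds go, one swap gives only two points at this position, so it remains open how an amine, a nitrile or a trifluoromethyl group on the same carbon would compare with chloro and nitro. From the compounds shown here alone, it is also open whether nitro in place of chloro would give a step of similar size at another carbon of the same ring, since this pair speaks for one position of the shared core alone.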